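A Bromo-to-Methyl Swap and Its Expected Cost

This account rests on a few compounds, and the source may have more. Where it says the series, first, only, none or still open, it means among the compounds named here.

Compound 1 `OCc1cn(Cc2ccccc2)c2ccccc12`: 112 nM
Compound 2 `OCc1cn(Cc2ccc(Br)cc2)c2ccccc12`: 31 nM

In a functional assay on NCI-H460 cells (Homo sapiens) for cytotoxicity, read by sulforhodamine B assay, with a stated time of 3 days (a higher number here means a weaker inhibitor, a lower number a stronger inhibitor), compound 1 gives 112 nM. Within the data shown here, in the same this assay compound 2 gives 31 nM, the lowest of the two numbers, and its only neighbour is compound 1, reached by the step of a 3.6-fold lower number from compound 1 to compound 2 (0.56 log units; beyond the scatter). Compound 3 `Cc1ccc(Cn2cc(CO)c3ccccc32)cc1` differs from compound 2 in one place: methyl in place of bromo on an aromatic carbon. Among the measured compounds shown here, only one measured step bears on this change, and it is indirect. The step of a 3.6-fold lower number from compound 1 to compound 2 (0.56 log units; beyond the scatter) shows that placing bromo at this position lowered the number well beyond the scatter, but no measurement shows what methyl does at the same position. A partial loss of that gain is the plainest expectation, while a number close to compound 2 cannot be excluded. Compound 3 is therefore expected to give 55 nM, within 22 nM to 140 nM, which means an expected step of a 1.8-fold higher number from compound 2 to compound 3 (0.25 log units; within the scatter).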

Compound 3, half-maximal inhibitory concentration: 31 nM
Estimate against measurement, compound 3: 1.8-fold (0.25 log units) above; the range from low to high includes it.
By their numbers in this assay, from the lowest: compounds 2 and 3 (each within the scatter of the next); then compound 1.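

The lower number at this position does not depend on bromo: in this assay, methyl in place of bromo gives no change at the digits printed from compound 2 to compound 3 (within the scatter). Set against the unsubstituted ring, methyl gives a 3.6-fold lower number from compound 1 to compound 3 (0.56 log units; beyond the scatter), a step of the same size as a 3.6-fold lower number from compound 1 to compound 2 (0.56 log units; beyond the scatter), so two different groups on this aromatic carbon, para to a large group, each set their compound apart from compound 1, and the two cannot be told apart here. Nothing available explains why bromo and methyl match at this position.

As far as these compounds go, whether other groups at this carbon would behave the same way remains open. An amine, a carboxylic acid or a longer chain such as propyl could show how far this tolerance extends.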